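Vero cell cytotoxicity: from compound 2 to compound 3

This account rests on a few compounds, and the source may have more. Where it says the series, first, only, none or still open, it means among the compounds named here.

Two compounds carry readings in an ADME assay on Vero cells (Chlorocebus sabaeus) for cytotoxicity, read by microscopy; on this read-out lower numbers stand for higher toxicity in this test and higher numbers for lower toxicity in this test. Compound 1 `CSc1nc(-c2ccccc2)c(C#N)c(N2CCN(c3ccnc4cc(Cl)ccc34)CC2)n1` gives only a limit in this assay, > 100000 nM. Going by the values given here, compound 2 `CSc1nc(NCCCCNc2ccnc3cc(Cl)ccc23)c(C#N)c(-c2cccc([N+](=O)[O-])c2)n1` gives 20000 nM in this assay and is the only compound with a number rather than a limit, so it stands alone on the scale, with the limit of > 100000 nM in this assay, at which 1 of the 2 values shown sits, as the sole other point of reference. Among the compounds with values here, compound 1 and compound 2 differ in more than one place, so no single step separates them; their values show only that compound 2 reaches a toxic concentration the assay can report while compound 1 does not.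

Compound 3 `COc1ccc(-c2nc(SC)nc(NCCCCNc3ccnc4cc(Cl)ccc34)c2C#N)cc1` is the next candidate. It differs from compound 2 in one place: 4-methoxyphenyl in place of 3-nitrophenyl on an aromatic carbon. Within the data shown here, no measured pair shows what such an exchange does in this assay, so the expected step is small, with at most a mild easing of toxicity, and a limit reading cannot be ruled out. Compound 3 is expected to give about 30000 nM in this assay, within 10000 nM to 100000 nM, which corresponds to an estimated 1.5-fold higher number from compound 2 to compound 3 (0.18 log units; within the scatter).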

Compound 3, minimum cytotoxic concentration: 20000 nM
For compound 3 the middle estimate is 1.5-fold (0.18 log units) above the measured one, and the stated range covers the measured number.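

In this assay, 4-methoxyphenyl in place of 3-nitrophenyl on the aromatic carbon ortho to a cyano group gives no change at the digits printed from compound 2 to compound 3 (within the scatter). Going by these compounds alone, this is the first single exchange that can be read at this position, and it shows that the reading does not separate these two substituted phenyl groups, although they differ both in the substituent and in where it sits on the phenyl ring; the step covers both differences together and cannot divide them. Nothing among the measurements shown accounts for this outcome.

Open, as far as these compounds go, is what a 4-nitrophenyl or a 3-methoxyphenyl group gives at this position, since either would tell the substituent apart from its place on the phenyl ring. Also open, from the compounds shown here alone, is whether the reading holds for an unsubstituted phenyl, for a phenyl carrying an amine or a carboxylic acid, or for a longer chain between the two amine nitrogens of compound 3.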